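Swapping the amide aryl group and watching cell tolerance

A few compounds are considered here, and "the series" means these few. Any claim that something is new, unique, unknown or untested is made for them only; others in the source may bear on it.

Compound 1 `CC(C)n1ncc2c(C(=O)Nc3cncnc3)cc(-c3cccs3)nc21` was assessed in an ADME assay on LLC-MK2 cells (Macaca mulatta) for cytotoxicity, read by spectrophotometry and crystal violet staining, with a stated time of 4 days (a lower number here means that less compound is tolerated, a higher number that more compound is tolerated), where compound 1 gives 20000 nM. Of the two numbers shown, that of compound 1 is the larger, yet the nearest, compound 2 `CC(C)n1ncc2c(C(=O)Nc3ccc(F)cc3)cc(C3CC3)nc21`, which in this assay gives 12500 nM, sits within the scatter, so no ordering is read from it. Compound 3 `CC(C)n1ncc2c(C(=O)Nc3cc(F)ccc3F)cc(-c3cccs3)nc21` differs from compound 1 by 2,5-difluorophenyl in place of pyrimidin-5-yl on an amide-type nitrogen. Among the measured compounds shown here, no comparable step has been measured, so only a small shift is expected: the step of a 1.3-fold lower number from compound 1 to compound 3 (0.12 log units; within the scatter) is expected to stay within the scatter. Compound 3 is estimated at 15000 nM, with a range from 6000 nM to 40000 nM.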

Compound 3, half-maximal cytotoxic concentration: 100000 nM
For compound 3 the middle estimate is 6.7-fold (0.82 log units) below the measured one; measured number above the stated range.
By their numbers in this assay, from the lowest: compounds 2 and 1 (each within the scatter of the next); then compound 3.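

At this amide-type nitrogen the aryl group does register in this assay: 2,5-difluorophenyl in place of pyrimidin-5-yl gives a 5.0-fold higher number from compound 1 to compound 3 (0.70 log units; beyond the scatter) and so moves the read-out beyond the scatter, which the earlier pair, differing in more than one place, could not show. The change exchanges a ring with two nitrogens for a fluorinated carbon ring, and no measurement shows what lies behind the shift. Left open is whether both fluorines are needed, as an unsubstituted phenyl would test. Also open, on these data alone, is how a pyridine ring or a methoxy-bearing phenyl would fare here.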